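Branching the Chain on the Core Nitrogen

A few compounds are considered here, and "the series" means these few. Any claim that something is new, unique, unknown or untested is made for them only; others in the source may bear on it.

Measured so far:
Compound 1 `CC(C)c1onc(-c2c(Cl)cccc2Cl)c1COc1ccc(-c2nc3ccc(C(=O)O)cc3n2-c2ccc(F)cc2)cc1` gives 32.2 nM in an assay on Huh-7 cells for agonist activity at Bile acid receptor (Homo sapiens), read by a luciferase reporter; a lower number here means that less compound is needed, a higher number that more compound is needed for the effect.
Compound 2 `CC(=O)N1CCC(n2c(-c3ccc(OCc4c(-c5c(Cl)cccc5Cl)noc4C(C)C)cc3)nc3ccc(C(=O)O)cc32)CC1` gives 1430 nM.
Compound 3 `CCCn1c(-c2ccc(OCc3c(-c4c(Cl)cccc4Cl)noc3C(C)C)cc2)nc2ccc(C(=O)O)cc21` gives 9.3 nM.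

Compound 3 stands lowest of the three numbers, since a 3.5-fold lower number from compound 1 to compound 3 (0.54 log units; beyond the scatter) and a 150-fold lower number from compound 2 to compound 3 (2.19 log units; beyond the scatter). Compound 4 `CC(C)Cn1c(-c2ccc(OCc3c(-c4c(Cl)cccc4Cl)noc3C(C)C)cc2)nc2ccc(C(=O)O)cc21` differs from compound 3 by methyl in place of hydrogen on a saturated chain carbon bound to two saturated chain carbons. For the measured compounds named here, no measured step makes this kind of change; each of them swaps the whole group on the aromatic nitrogen, where a 44-fold higher number from compound 1 to compound 2 (1.65 log units; beyond the scatter) was large and a 3.5-fold lower number from compound 1 to compound 3 (0.54 log units; beyond the scatter) was modest. Adding a single carbon to a chain that already gives the lowest number is expected to shift the result little, likely within the scatter, so a 1.3-fold higher number from compound 3 to compound 4 (0.11 log units; within the scatter) is expected. For compound 4 the estimate is 12 nM, with a range from 4 nM to 40 nM.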

Compound 4, half-maximal effective concentration: 5.26 nM
Compound 4: middle estimate off by 2.3-fold (0.36 log units), on the high side; the range from low to high includes it.
By their numbers in this assay, from the lowest: compounds 4 and 3 (each within the scatter of the next); then compound 1; then compound 2.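

Propyl and isobutyl on the aromatic nitrogen cannot be told apart here (a 1.8-fold lower number from compound 3 to compound 4 (0.25 log units; within the scatter)), so methyl in place of hydrogen on this saturated chain carbon is tolerated. The branched chain also stays clearly ahead of the larger groups on that nitrogen (a 6.1-fold lower number from compound 1 to compound 4 (0.79 log units; beyond the scatter); a 270-fold lower number from compound 2 to compound 4 (2.43 log units; beyond the scatter)). No measurement at hand explains this tolerance.

On these data alone, it remains open whether a longer chain such as pentyl would keep the number this low. A chain ending in an amine or a carboxylic acid is equally untested by the compounds shown.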